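Swapping the aryl amide in a dopamine receptor series

This account rests on a few compounds, and the source may have more. Where it says the series, first, only, none or still open, it means among the compounds named here.

Compound 1 `CCc1cccc(NC(=O)CN2CCC(c3cccc[n+]3[O-])CC2)c1` is tested in a functional assay on HEK293 cells for agonist activity at D(4) dopamine receptor (Homo sapiens), read by FLIPR (on this read-out higher numbers stand for larger maximal responses and lower numbers for smaller maximal responses), where compound 1 gives 62%. Among the three compounds measured, compound 1 stands second highest: compound 2 `Cc1cccc(Cl)c1NC(=O)CN1CCC(c2ccccn2)CC1` gives 70%, a difference that lies within the scatter, while compound 3 `CC(C)Oc1cccc(NC(=O)CN2CCC(c3cccc[n+]3[O-])CC2)c1` gives 48%. For the measured compounds named here, the only step recorded between measured neighbours is a number 14 percentage points lower from compound 1 to compound 3 (beyond the scatter), a modest loss.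

Compound 4 `Cc1cccc(C)c1NC(=O)CN1CCC(c2cccc[n+]2[O-])CC1` is not yet measured. It differs from compound 1 by 2,6-dimethylphenyl in place of 3-ethylphenyl on an amide-type nitrogen. Going by the values given here, no measured step covers this exact exchange. Compound 2 also carries two groups flanking the amide nitrogen, but compound 2 differs from compound 1 in more than one place, so its value only shows that such a pattern can sit near the top of this small set. Among the compounds with values here, the one recorded step, from compound 1 to compound 3, concerns a different change and gives no direct guide.

Compound 4 is therefore expected to stay close to compound 1, with an estimated step of a number 3 percentage points higher from compound 1 to compound 4 (within the scatter), giving an estimate of 65% in a range from 50% to 80%.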

Compound 4, largest response reached (reported as efficacy), in percent of the reference or control that the assay uses: 68%
Compound 4: middle estimate off by 3 percentage points, on the low side; the range from low to high includes it.
By their numbers in this assay, from the lowest: compound 3; then compounds 1, 4 and 2 (each within the scatter of the next).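

In this assay the exchange of 3-ethylphenyl for 2,6-dimethylphenyl on the amide-type nitrogen gives a number 6 percentage points higher from compound 1 to compound 4 (within the scatter) and thus shows that this position accepts a group of the same size, with its carbons arranged differently, without a shift that can be told from the scatter. For the compounds shown here, until now the only step read at this aryl group was a loss, a number 14 percentage points lower from compound 1 to compound 3 (beyond the scatter) in the same assay, so the maximal response is not lost with every exchange made here. Why the response holds cannot be said, as nothing measured on these compounds bears on it.

As far as these compounds go, whether a plain phenyl, a 2,6-dichlorophenyl, or an aryl group carrying an amine or a carboxylic acid would keep the response stays open. So does the size of the step on removing the oxygen of the N-oxide alone.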